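The source may report more compounds than this note shows. Statements on the series, on what has been measured and on what is new or still open speak of the compounds shown alone.

Measured compounds:
- compound 1, `Cc1ccc(OCC(=O)N(Cc2cccs2)c2ccn[nH]2)cc1`: 0.2 nM
- compound 2, `Cc1ccc(OCC(=O)N(Cc2cccs2)C2CC2)cc1`: 8 nM
- compound 3, `Cc1ccc(OCC(=O)N(Cc2cccs2)c2ccn(C)n2)cc1`: 855 nM

In an assay on HEK293 cells for agonist activity at transient receptor potential cation channel subfamily M member 8 (Homo sapiens), read by fluorescence and calcium flux, with a stated time of 15 min (on this read-out lower numbers stand for an effect already at smaller amounts and higher numbers for an effect only at larger amounts of compound), compound 3 gives 855 nM, the highest of the three numbers; its nearest neighbour is compound 2, with the step of a 110-fold higher number from compound 2 to compound 3 (2.03 log units; beyond the scatter) lying between them, and the furthest is compound 1, separated by a 4300-fold higher number from compound 1 to compound 3 (3.63 log units; beyond the scatter). Compound 4, `Cc1ccc(OCC(=O)N(Cc2cccs2)c2ccccc2)cc1`, has not yet been measured. It differs from compound 3 in one place: phenyl in place of 1-methyl-1H-pyrazol-3-yl on an amide-type nitrogen.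

Going by the values given here, two measured steps bear on this change. The replacement of the 1H-pyrazol-5-yl by cyclopropyl gave a 40-fold higher number from compound 1 to compound 2 (1.60 log units; beyond the scatter), and the replacement of cyclopropyl by 1-methyl-1H-pyrazol-3-yl gave a 110-fold higher number from compound 2 to compound 3 (2.03 log units; beyond the scatter). Both show that the group on this amide-type nitrogen moves the read-out strongly, and that the 1-methyl-1H-pyrazol-3-yl sits at the weak end. Among the compounds with values here, no measured compound carries a phenyl, so the direction rests on the observation that every other group tested here gave a lower number than compound 3. The expected step is an 8.6-fold lower number from compound 3 to compound 4 (0.93 log units; beyond the scatter), a move toward compound 2 but with wide uncertainty. Compound 4 is therefore estimated at 100 nM, within 15 nM to 800 nM.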

Compound 4, half-maximal effective concentration: 23 nM
Compound 4: the middle estimate sits 4.3-fold (0.64 log units) above what was measured, within the range that was stated.
By their numbers in this assay, from the lowest: compound 1; then compound 2; then compound 4; then compound 3.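

In this assay, the phenyl shows that an aromatic ring on this amide-type nitrogen need not sit at the weak end, with a 37-fold lower number from compound 3 to compound 4 (1.57 log units; beyond the scatter) for an exchange that leaves the count of 6 heavy atoms unchanged. Phenyl also lands near cyclopropyl, though a 2.9-fold higher number from compound 2 to compound 4 (0.46 log units; beyond the scatter) keeps the two apart, so a six-membered aromatic ring of carbon only and the cyclopropyl give similar but distinct results here. The 1H-pyrazol-5-yl remains clearly apart from phenyl, with a 120-fold higher number from compound 1 to compound 4 (2.06 log units; beyond the scatter) showing that a ring alone does not reach the number of compound 1.

Nothing among the data given accounts for any of these steps. As far as these compounds go, whether a pyridinyl ring, an aminophenyl group or a longer alkyl chain on this nitrogen would approach compound 1 or fall toward compound 3 remains open.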